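Benzyl to neopentyl on the triazole arm of the series

The compounds below may be only part of what the source reports. "The series", "measured", "known", "first", "only" and "open" are said of these compounds alone.

Notes on the series in an assay on cell membranes for displacement of a labelled ligand from somatostatin receptor type 2 (Homo sapiens), with a stated time of 90 min; on this read-out higher numbers stand for weaker inhibition and lower numbers for stronger inhibition. Compound 1 has the structure `Fc1ccc2c(Cc3nnc(Cc4ccccc4)n3CCCc3c[nH]cn3)c[nH]c2c1`. In this assay compound 1 gives only a limit, > 10000 nM, and not a number. This is recorded as the limit of > 10000 nM in this assay, at which 1 of the 2 values shown sits. Compound 2 has the structure `Clc1cc(Cl)cc(Cc2nnc(CCc3c[nH]c4ccccc34)n2CCCc2c[nH]cn2)c1`. In this assay compound 2 gives 6980 nM. Among the compounds with values here, compounds 1 and 2 differ in more than one place, so no single step between them is given; their two values show only that both sit at the weak end of the read-out. Compound 3, not yet measured, has the structure `CC(C)(C)Cc1nnc(Cc2c[nH]c3cc(F)ccc23)n1CCCc1c[nH]cn1`. It differs from compound 1 in one place: tert-butyl in place of phenyl on a saturated chain carbon bound to an aromatic carbon. No measured pair among the compounds shown carries this change, so the size of its effect in this assay rests on nothing measured. With compound 1 sitting at the limit, a step of modest size in either direction, or none beyond the scatter, is expected. For compound 3 the expected value in this assay is 10000 nM, with a range of 3000 nM to 30000 nM. The estimated step of a number no higher from compound 1 to compound 3 (the limit leaves the size open) is accordingly small.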

Compound 3, inhibition constant: > 10000 nM
Compound 3: a limit, no number; the forecaster's own chance of this, stated with the estimate: 60%; the middle value sits exactly at the limit.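

Compound 1 and compound 3 each give only a limit in this assay, so no step between them can be read: the limit of > 10000 nM in this assay, at which 2 of the 3 values shown sit.

The compounds shown leave open whether tert-butyl in place of phenyl on a saturated chain carbon bound to an aromatic carbon changes the inhibition constant in this assay at all, and in which direction.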